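This account rests on a few compounds, and the source may have more. Where it says the series, first, only, none or still open, it means among the compounds named here.

Two members of this series have numbers in an assay with Cystic fibrosis transmembrane conductance regulator (Rattus norvegicus) as the target (a lower number here means tighter binding, a higher number weaker binding), so far. Compound 1 `COC(=O)C1CC(c2ccccc2OCc2ccc(Br)cc2)=NO1` gives 73000 nM in this assay, and compound 2 `COc1ccc(COc2ccccc2C2=NOC(CCl)C2)cc1` gives 59000 nM in this assay; compound 2 carries the lower of the two numbers, yet the gap to compound 1 lies within the scatter, so the two are read as equivalent. Compound 3 `COC(=O)C1CC(c2ccccc2OCc2ccc(OC)cc2)=NO1` is the next entry and differs from compound 2 in one place: methoxycarbonyl in place of chloromethyl on a saturated ring carbon. Among the measured compounds shown here, no single-change step between measured compounds is available, so the size of this change cannot be read from the series; the methoxycarbonyl it introduces is the group already present in compound 1, whose number in this assay sits close to that of compound 2. No step beyond the scatter is therefore expected from compound 2 to compound 3, a 1.2-fold higher number from compound 2 to compound 3 (0.07 log units; within the scatter). For compound 3 the expected number in this assay is 70000 nM, with a likely range from 35000 nM to 140000 nM.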

Compound 3, dissociation constant: 50000 nM
The estimate for compound 3 lay 1.4-fold (0.15 log units) above the measured number; measured number inside the range.
By their numbers in this assay, from the lowest: compounds 3, 2 and 1 (each within the scatter of the next).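

In this assay, methoxycarbonyl in place of chloromethyl on the saturated ring carbon gives a 1.2-fold lower number from compound 2 to compound 3 (0.07 log units; within the scatter) and so provides a direct reading at this position: the two groups are not separated here, despite their different heavy-atom and hydrogen-bond acceptor counts. Methoxy in place of bromo on an aromatic carbon gives a 1.5-fold lower number from compound 1 to compound 3 (0.16 log units; within the scatter) and likewise shows no separation at that second position. No evidence is available that bears on these results.

Going by these compounds, whether a carboxylic acid, an amine or a longer chain on the saturated ring carbon would give a step beyond the scatter remains open. Also open, on these data alone, is whether a hydroxyl or an amine in place of methoxy or bromo on the aromatic carbon would shift the number in this assay beyond the scatter.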